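Swapping the Aryl Group on a Weak Inhibitor Series

The source may hold more compounds than are shown below. What is called first, only, known or untested is meant among the compounds shown, and "the series" means these compounds.

Measured in a physicochemical assay, read by spectrophotometry, with a stated time of 30 min; a lower number here means a stronger inhibitor, a higher number a weaker inhibitor:
- Compound 1 `O=C(CCc1nc2ccccc2c(=O)[nH]1)N/N=C/c1ccc([N+](=O)[O-])cc1`: 328000000 nM
- Compound 2 `COc1cc(/C=N/NC(=O)CCc2nc3ccccc3c(=O)[nH]2)ccc1O`: 204000000 nM

Within the data shown here, only two compounds have numbers so far, and they cannot be told apart. Among the measured compounds shown here, the single measured step is a 1.6-fold lower number from compound 1 to compound 2 (0.21 log units; within the scatter), which lies within the scatter of repeated measurements. Compound 2 therefore stands level with compound 1 on the evidence available.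

The next compound, compound 3 `COc1ccc(/C=N/NC(=O)CCc2nc3ccccc3c(=O)[nH]2)cc1`, keeps the shared core and alters only the group on a carbon with a double bond to nitrogen: 4-methoxyphenyl in place of 4-hydroxy-3-methoxyphenyl on a carbon with a double bond to nitrogen. In words, 4-methoxyphenyl takes the place of 4-hydroxy-3-methoxyphenyl.

For the measured compounds named here, the one measured step bears on this change, since it was made at the same place. Replacing 4-nitrophenyl with 4-hydroxy-3-methoxyphenyl gave a 1.6-fold lower number from compound 1 to compound 2 (0.21 log units; within the scatter), so no shift beyond the scatter is expected in this assay, in either direction. One step is thin evidence, so the range stays wide.

The estimate corresponds to a 1.2-fold higher number from compound 2 to compound 3 (0.07 log units; within the scatter), an expected step within the scatter. For compound 3 the estimated value is 240000000 nM, with an expected range of 110000000 nM to 480000000 nM.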

Compound 3, half-maximal inhibitory concentration: 214000000 nM
For compound 3 the middle estimate is 1.1-fold (0.05 log units) above the measured one, and the stated range covers the measured number.
By their numbers in this assay, from the lowest: compounds 2, 3 and 1 (each within the scatter of the next).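

Compound 3 shows that this position tolerates a further kind of change in this assay: 4-methoxyphenyl, with 0 hydrogen-bond donors, in place of 4-hydroxy-3-methoxyphenyl, with 1 hydrogen-bond donor, gives only a small step (a 1.0-fold higher number from compound 2 to compound 3 (0.02 log units; within the scatter)). The comparison with the first compound also isolates a single swap on the ring, methoxy in place of nitro on an aromatic carbon, and that step stays small as well (a 1.5-fold lower number from compound 1 to compound 3 (0.19 log units; within the scatter)), so all three aryl groups shown on a carbon with a double bond to nitrogen remain indistinguishable in this assay. Nothing measured here offers an explanation for how closely these numbers agree.

The compounds shown leave open whether any group at this place can move the number beyond the scatter, such as a phenyl ring carrying an amine or a carboxylic acid, or a longer open carbon chain in place of the ring. They also leave open how 4-hydroxyphenyl would compare with 4-methoxyphenyl, and whether a change away from this place, on the shared core, would matter more.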